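Shortening the Chain Between Compound 3 and Compound 4

A few compounds are considered here, and "the series" means these few. Any claim that something is new, unique, unknown or untested is made for them only; others in the source may bear on it.

Compound 1 `CC/N=C(\S)NCCCCCn1nc(-c2ccccc2)ccc1=O` gives 51.8 mg/kg in a functional assay on the whole organism (stomach) with Rattus norvegicus as the target; on this read-out lower numbers stand for an effect already at smaller amounts and higher numbers for an effect only at larger amounts of compound. Compound 2 `C/N=C(/NC#N)NCCCCCn1nc(-c2ccccc2)ccc1=O` gives 100 mg/kg in this assay, and the step of a 1.9-fold higher number from compound 1 to compound 2 (0.29 log units; within the scatter) stays within the scatter, so the two values are read as alike. Compound 3 `C/N=C(/NC#N)NCCCCCn1nc(-c2ccccc2)c(C)cc1=O` is reported in this assay only as a limit, > 100 mg/kg. The step of a number no lower from compound 2 to compound 3 (the limit leaves the size open) therefore has no readable size. On the numbers shown, compound 3 thus stands at the boundary of the assay, at the limit of > 100 mg/kg in this assay, at which 1 of the 3 values shown sits, and its true value is not pinned down.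

Compound 4 `C/N=C(/NC#N)NCCCCn1nc(-c2ccccc2)c(C)cc1=O` differs from compound 3 by a group of 7 heavy atoms (3 carbon, 4 nitrogen; no ring) in place of a group of 8 heavy atoms (4 carbon, 4 nitrogen; no ring), on a saturated chain carbon, four bonds along the chain from an aromatic nitrogen. Within the data shown here, none of the measured steps touches this chain: one concerns the group on the amine nitrogen and lies within the scatter, the other concerns the methyl on the aromatic carbon and ends at a limit. Neither gives a direction or a size for the change in this assay, so the expectation rests on where compound 3 stands and carries a wide range. For compound 4 the expected value in this assay is 110 mg/kg, with a range from 45 mg/kg to 300 mg/kg. This estimate amounts to an expected step that the limit leaves unreadable from compound 3 to compound 4, not beyond the scatter in either direction. A sizeable chance remains that compound 4 is again reported only as a limit.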

Compound 4, dose for half-maximal effect: > 100 mg/kg
Compound 4 ended at the assay's limit; the forecaster's own chance of this, stated with the estimate: 50%; the middle value lies beyond the limit too.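

In this assay, among these compounds, compound 3 and compound 4 are both reported only as limits, so no step between them can be read: the limit of > 100 mg/kg in this assay, at which 2 of the 4 values shown sit. The compounds shown leave open where the true values of compound 3 and compound 4 lie, and whether the change in the chain shifts the effect at all, or in which direction.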